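This account rests on a few compounds, and the source may have more. Where it says the series, first, only, none or still open, it means among the compounds named here.

Of the compounds shown here, three of one series have been tested in an ADME assay on cells (Peritoneal macrophage cell, Mus musculus) for cytotoxicity, read by fluorescence and resazurin assay, with a stated time of 3 days; a higher number here means that more compound is tolerated, a lower number that less compound is tolerated. Compound 1, with the structure `O=C(Nc1cc(-c2ccccn2)n[nH]1)N1CCC(c2ccc(Cl)cc2)CC1`, gives in this assay only a limit, > 55000 nM. Compound 2, with the structure `COc1ccccc1C(=O)Nc1[nH]nc(-c2ccccn2)c1C1CC1`, likewise gives only a limit, > 51000 nM. Compound 3, with the structure `CC(C)Oc1cc(C(=O)Nc2cc(-c3ccccn3)n[nH]2)cc(C(=O)N2CCCC2)c1`, also gives only a limit, > 40300 nM. Compound 2 therefore stands where every measured compound stands: all three values rest at the limits of the assay, as the limit of > 40300 nM in this assay, at which 1 of the 3 values shown sits, the limit of > 51000 nM in this assay, at which 1 of the 3 values shown sits, and the limit of > 55000 nM in this assay, at which 1 of the 3 values shown sits, record, and no numerical reading separates any of them from the others.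

Compound 4, with the structure `O=C(NCc1ccccc1)Nc1[nH]nc(-c2ccccn2)c1C1CC1`, has not yet been measured. It differs from compound 2 in one place: benzylamino in place of 2-methoxyphenyl on a carbonyl carbon. Within the data shown here, no step between two measured compounds is available to show how such a change acts in this assay, so the size and direction of its effect cannot be read from the data. Compound 2 itself sits at a limit, > 51000 nM. The step is therefore expected to be an at least 1.0-fold lower number from compound 2 to compound 4 (0.00 log units; that floor lies within the scatter), which lies within the usual scatter. Compound 4 is expected to give about 50000 nM, in a range from 20000 nM to 100000 nM, and quite possibly only a limit again.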

Compound 4, half-maximal cytotoxic concentration: > 45000 nM
Compound 4 was reported as a limit (the forecaster's own chance of this, stated with the estimate: 80%); the middle value is on the limit's open side.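

In this assay compound 2 and compound 4 each give only a limit, so no new step can be read from benzylamino in place of 2-methoxyphenyl on the carbonyl carbon. The compounds shown leave open at what concentration any of them harms the cells, and whether this change alters that concentration.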